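A few compounds are considered here, and "the series" means these few. Any claim that something is new, unique, unknown or untested is made for them only; others in the source may bear on it.

Working notes on the series. Compound 1 `Clc1cc(N2CC[C@@H]3CN[C@@H]3C2)cnc1Cl` and compound 2 `Cc1cc(N2CC[C@@H]3CN[C@@H]3C2)cnc1Cl` share one core; compound 3 `Clc1cc(N2C[C@@H]3CCNC[C@@H]32)cnc1Cl` and compound 4 `Cc1cc(N2C[C@@H]3CCNC[C@@H]32)cnc1Cl` share another, with the same atoms joined differently; the difference between the two cores is not broken down here. In a functional assay on HEK293 cells for agonist activity at Neuronal acetylcholine receptor; alpha4/beta2 (Homo sapiens), read by FLIPR (on this read-out higher numbers stand for an effect only at larger amounts of compound and lower numbers for an effect already at smaller amounts), compound 1 gives 82 nM, compound 2 gives 47 nM, and compound 3 gives 271 nM. The change methyl in place of chloro on an aromatic carbon made a step of a 1.7-fold lower number from compound 1 to compound 2 (0.24 log units; within the scatter). Compound 4 carries the same change on its own core, (methyl in place of chloro on an aromatic carbon); the place line is word for word the same. Within the data shown here, with only one measured example of this change, the expected step from compound 3 to compound 4 in this assay is taken as a 1.7-fold lower number from compound 3 to compound 4 (0.23 log units; within the scatter), resting on the step of a 1.7-fold lower number from compound 1 to compound 2 (0.24 log units; within the scatter). Compound 4 is accordingly expected to give about 160 nM, between 80 nM and 320 nM.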

Compound 4, half-maximal effective concentration: 76.1 nM
Compound 4: the middle estimate sits 2.1-fold (0.32 log units) above what was measured; the measured number lies below the stated range.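

Methyl in place of chloro on an aromatic carbon gives a 3.6-fold lower number from compound 3 to compound 4 (0.55 log units; beyond the scatter) in this assay. Set beside the step on the other core, the new step does not differ from it beyond what repeated measurement allows: the same change on two cores in this assay, a 1.7-fold lower number (0.24 log units; within the scatter) from compound 1 to compound 2 and a 3.6-fold lower number (0.55 log units; beyond the scatter) from compound 3 to compound 4, 2.0-fold (0.31 log units) apart, within the scatter of two such steps. This fits the change carrying over between these two cores, but the step on the core of compound 1 lies within the scatter, and two pairs neither set a rule for other cores nor explain the size of either step.

Open, as far as these compounds go, is how groups other than chloro and methyl at this place, such as fluoro, a nitrile or an amine, would read in this assay. Also open, from the compounds shown here alone, is whether the same change holds on any further core.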